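Methoxy replacing methylamino on a furanyl nucleoside core

The source may report more compounds than this note shows. Statements on the series, on what has been measured and on what is new or still open speak of the compounds shown alone.

Measured compounds:
Compound 1 `COc1ncnc2c1c(-c1ccsc1)cn2[C@@H]1O[C@H](CO)[C@@H](O)[C@H]1O` — 64300 nM
Compound 2 `CNc1ncnc2c1c(-c1ccco1)cn2[C@@H]1O[C@H](CO)[C@@H](O)[C@H]1O` — 5040 nM

In an ADME assay on BJ cells (Homo sapiens), read by MTT assay, with a stated time of 72 h (on this read-out lower numbers stand for stronger inhibition and higher numbers for weaker inhibition), compound 2 gives 5040 nM, the lowest of the two numbers recorded. In this assay, among the compounds with values here, compound 1 gives 64300 nM, a higher number beyond the scatter, though the two compounds differ in more than one place and no single step connects them. Compound 3 `COc1ncnc2c1c(-c1ccco1)cn2[C@@H]1O[C@H](CO)[C@@H](O)[C@H]1O` has not been measured. It differs from compound 2 as follows: methoxy in place of methylamino on an aromatic carbon. Compound 1 carries the same methoxy group and sits at the weak end of the two numbers, which suggests the direction. Compound 3 is therefore expected to come out weaker than compound 2, with an estimated step of a 6.9-fold higher number from compound 2 to compound 3 (0.84 log units; beyond the scatter). The estimate for compound 3 in this assay is 35000 nM, within a range of 8000 nM to 120000 nM; this rests on two compounds only and is uncertain.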

Compound 3, half-maximal inhibitory concentration: 430 nM
Compound 3: the middle estimate sits 81-fold (1.91 log units) above what was measured, outside the stated range (below it).
By their numbers in this assay, from the lowest: compound 3; then compound 2; then compound 1.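

In this assay, methoxy in place of methylamino gives a 12-fold lower number from compound 2 to compound 3 (1.07 log units; beyond the scatter) with the furan-2-yl group held constant, so at this position methoxy goes with the stronger inhibition, a direction that the earlier pair, differing in more than one place, could not show. With methoxy held constant, furan-2-yl in place of thiophen-3-yl gives a 150-fold lower number from compound 1 to compound 3 (2.17 log units; beyond the scatter) on the same core, so the high number of compound 1 goes with its thiophen-3-yl group and not with methoxy. Nothing given here accounts for either step.

As far as these compounds go, whether ethoxy, dimethylamino or an unsubstituted amine at this position would follow methoxy or methylamino remains open. From the compounds shown here alone, it is also open whether the change from methylamino to methoxy would run the same way with thiophen-3-yl on the core.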